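The compounds below may be only part of what the source reports. "The series", "measured", "known", "first", "only" and "open" are said of these compounds alone.

- Compound 1 `COc1ccc(/C=N/NC(=O)Nc2cc3c(Nc4ccc(F)c(Cl)c4)ncnc3cc2O[C@H]2CCOC2)c(OC)c1OC`: 25600 nM
- Compound 2 `O=C(N/N=C/c1cc(Br)c(O)c(Br)c1)Nc1cc2c(Nc3ccc(F)c(Cl)c3)ncnc2cc1O[C@H]1CCOC1`: 6160 nM

Among the compounds with values here, in a functional assay on PC-3 cells (Homo sapiens) for cytotoxicity, read by MTT assay, with a stated time of 72 h (on this read-out higher numbers stand for weaker inhibition and lower numbers for stronger inhibition), compound 2 gives 6160 nM, the lowest of the two numbers measured so far. Compound 3 `O=C(N/N=C/c1ccc(O)cc1O)Nc1cc2c(Nc3ccc(F)c(Cl)c3)ncnc2cc1O[C@H]1CCOC1` differs from it by one change, 2,4-dihydroxyphenyl in place of 3,5-dibromo-4-hydroxyphenyl on a carbon with a double bond to nitrogen: 2,4-dihydroxyphenyl in place of 3,5-dibromo-4-hydroxyphenyl. Within the data shown here, only one measured step bears on this place: a 4.2-fold lower number from compound 1 to compound 2 (0.62 log units; beyond the scatter), which is modest but beyond the scatter. With the 3,5-dibromo-4-hydroxyphenyl group gone, a modest move to a higher number is expected, an estimated 2.4-fold higher number from compound 2 to compound 3 (0.39 log units; beyond the scatter). For compound 3 the estimated value is 15000 nM, with an expected range from 5000 nM to 40000 nM.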

Compound 3, half-maximal inhibitory concentration: 7540 nM
For compound 3 the middle estimate is 2.0-fold (0.30 log units) above the measured one; the measured number falls inside the stated range.
By their numbers in this assay, from the lowest: compounds 2 and 3 (each within the scatter of the next); then compound 1.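

Swapping 3,5-dibromo-4-hydroxyphenyl for 2,4-dihydroxyphenyl in this assay gives a 1.2-fold higher number from compound 2 to compound 3 (0.09 log units; within the scatter), so the bromine atoms are not required for the reading at this place. Against 2,3,4-trimethoxyphenyl, the same group gives a 3.4-fold lower number from compound 1 to compound 3 (0.53 log units; beyond the scatter), so both hydroxyl-bearing phenyl groups shown read lower than the trimethoxyphenyl group. Nothing available accounts for these differences. From the compounds shown here alone, it remains open whether an unsubstituted phenyl, or a phenyl carrying an amine or a carboxylic acid, would match these two groups in this assay.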